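The source may hold more compounds than are shown below. What is called first, only, known or untested is meant among the compounds shown, and "the series" means these compounds.

Measured compounds in the series:
- compound 1 `CCCc1nnc(SCc2ccccc2Cl)n1N1C(=O)c2ccccc2C1=O`: in a functional assay on PC-3M cells (Homo sapiens) for cytotoxicity, read by MTT assay, with a stated time of 48 h (a lower number here means a stronger inhibitor, a higher number a weaker inhibitor), compound 1 gives > 200000 nM, which is a limit of the assay and not a number.
- compound 2 `C=CCSc1nnc(-c2cc(OC)c(OC)c(OC)c2)n1N1C(=O)c2ccccc2C1=O`: in this assay compound 2 gives > 200000 nM, again a limit.
- compound 3 `COc1cc(-c2nnc(SCc3ccccc3Cl)n2N2C(=O)c3ccccc3C2=O)cc(OC)c1OC`: in this assay compound 3 gives > 200000 nM, also a limit.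

Compound 3 therefore stands at the limit, and every measured value in the series sits there too (the limit of > 200000 nM in this assay, at which 3 of the 3 values shown sit). The step from compound 1 to compound 3, a step that the two limits leave unreadable from compound 1 to compound 3, and the step from compound 2 to compound 3, a step that the two limits leave unreadable from compound 2 to compound 3, are both unreadable: two limits give no size and no direction.

Compound 4 `C#CCSc1nnc(-c2cc(OC)c(OC)c(OC)c2)n1N1C(=O)c2ccccc2C1=O` differs from compound 3 by ethynyl in place of 2-chlorophenyl on a saturated chain carbon bound to a sulfur. The step from compound 2 to compound 3 bears on this most closely, as it also exchanges the group on the saturated chain carbon bound to a sulfur, but it is unreadable, and the step from compound 1 to compound 3 adds nothing readable either. No step beyond the scatter can be predicted in this assay from these data, and the expectation is that compound 4 will again return only a limit.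

The estimate for compound 4 in this assay is 300000 nM, expected to lie between 100000 nM and 1000000 nM. The expected step from compound 3 to compound 4 is a step that the limit leaves unreadable from compound 3 to compound 4.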

Compound 4, half-maximal inhibitory concentration: > 200000 nM
Compound 4: no number, only a limit; the forecaster's own chance of this, stated with the estimate: 85%; the middle value does not contradict the limit.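

In this assay compound 4 gives > 200000 nM, a limit and not a number. Among the compounds shown here, no step from compound 2 or compound 3 to compound 4 can be read. The compounds shown leave open whether any group on a saturated chain carbon bound to a sulfur would give a readable number in this assay, as the series stays at one limit: the limit of > 200000 nM in this assay, at which 4 of the 4 values shown sit.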